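This account rests on a few compounds, and the source may have more. Where it says the series, first, only, none or still open, it means among the compounds named here.

Measured in a functional assay on HeLa cells for antagonist activity at G-prodeshotein coupled receptor 4 (Homo sapiens), read by HTRF and cAMP accumulation, with a stated time of 15 min; a higher number here means a weaker inhibitor, a lower number a stronger inhibitor:
compound 1 `CCc1nn2c(C)cc(C)nc2c1Cc1ccc(CCCC2(O)CCN(C(C)C)CC2)cc1` gives 63 nM
compound 2 `CCc1nn2c(C)cc(C)nc2c1Cc1ccc(-c2nnc(N3CCNCC3)o2)cc1` gives 368 nM

Compound 1 carries the lower of the two numbers; compound 2 sits at a higher number, and that gap lies beyond the usual scatter of repeated measurements of this kind. Within the data shown here, the two compounds share their core but differ in the whole group attached to the far end of the molecule, so no step between measured compounds that differ in one place is available, and nothing can be said about the weight of any single change from these two alone.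

Compound 3 `CCc1nn2c(C)cc(C)nc2c1Cc1ccc(CCCC2(O)CCNCC2)cc1` is not yet measured in this assay. It comes from compound 1 by the change (hydrogen in place of isopropyl on an amine nitrogen in a ring). Among the measured compounds shown here, no measured pair shows this change, so its size has to be judged without a precedent. The hydroxy group and the rest of the molecule stay as in compound 1, and compound 1 gives 63 nM as the starting point. A modest shift toward a higher number is expected, a 2.2-fold higher number from compound 1 to compound 3 (0.35 log units; beyond the scatter), at the edge of the scatter rather than clearly beyond it. For compound 3 the estimate is 140 nM, with a range from 45 nM to 450 nM.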

Compound 3, half-maximal inhibitory concentration: 50 nM
Compound 3: the middle estimate sits 2.8-fold (0.45 log units) above what was measured; measured number inside the range.
By their numbers in this assay, from the lowest: compounds 3 and 1 (each within the scatter of the next); then compound 2.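

In this assay, among these compounds, hydrogen in place of isopropyl on the amine nitrogen in the ring gives a 1.3-fold lower number from compound 1 to compound 3 (0.10 log units; within the scatter) and so compound 1 and compound 3 cannot be told apart, which is the first reading of any single change. At this position the isopropyl group, with its 3 carbons, is therefore not needed to hold the number, and the ring nitrogen bearing hydrogen serves as well as the one bearing isopropyl, a statement that holds only for this pair, with the hydroxy group and the rest of the molecule the same in both. Nothing at hand gives a reason for this outcome.

On these data alone, two groups on one nitrogen say little about the position as a whole, so it remains open whether a benzyl or an acetyl group there would read the same as hydrogen and isopropyl. As far as these compounds go, the weight of the other parts of the side chain also remains open, in particular what a methoxy group in place of the hydroxy group, or a longer chain leading to the ring, would do to the number.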